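The source may report more compounds than this note shows. Statements on the series, on what has been measured and on what is new or still open speak of the compounds shown alone.

In a physicochemical assay for solubility, read by spectrophotometry, measured as kinetic solubility, at pH 8, tested at 500 uM (on this read-out lower numbers stand for lower solubility and higher numbers for higher solubility), compound 1 `CN1CCC(CNS(=O)(=O)c2ccccc2Nc2cc(-c3ccc4ccn(C)c4c3)c3nccnc3c2)C1` gives 35 ug/mL
Compound 2 `Cn1ccc2ccc(-c3cc(Nc4cnccc4C(=O)NCc4cncnc4)cc4nccnc34)cc21` gives 233 ug/mL
Compound 3 `CC(=O)N1CCCC(NC(=O)c2ccncc2Nc2cc(-c3ccc4ccn(C)c4c3)c3nccnc3c2)C1` gives 212 ug/mL

Compound 3 stands level with compound 2 within the scatter, and both numbers lie well over that of compound 1. The next compound, compound 4 `CN1CCC(CNC(=O)c2ccncc2Nc2cc(-c3ccc4ccn(C)c4c3)c3nccnc3c2)C1`, has (1-methylpyrrolidin-3-yl)methyl in place of 1-acetylpiperidin-3-yl on an amide-type nitrogen, ((1-methylpyrrolidin-3-yl)methyl in place of 1-acetylpiperidin-3-yl on an amide-type nitrogen). The closest measured precedent is another swap on an amide-type nitrogen, a 1.1-fold lower number from compound 2 to compound 3 (0.04 log units; within the scatter), and it stayed within the scatter. Compound 1 also carries (1-methylpyrrolidin-3-yl)methyl and gives 35 ug/mL, but it differs from compound 4 elsewhere too, so it serves only as a warning that a much lower number is possible. In this assay no step beyond the scatter is therefore expected, and any drift is expected to be downward. The expected change is a 1.1-fold lower number from compound 3 to compound 4 (0.05 log units; within the scatter). The estimate for compound 4 is 190 ug/mL, with an expected range of 90 ug/mL to 255 ug/mL.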

Compound 4, solubility: 246 ug/mL
Estimate against measurement, compound 4: 1.3-fold (0.11 log units) below; the measured number falls inside the stated range.
By their numbers in this assay, from the lowest: compound 1; then compounds 3, 2 and 4 (each within the scatter of the next).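

In this assay, putting (1-methylpyrrolidin-3-yl)methyl in place of 1-acetylpiperidin-3-yl on the amide-type nitrogen gives a 1.2-fold higher number from compound 3 to compound 4 (0.06 log units; within the scatter) and so leaves the reading unmoved. Set against the (pyrimidin-5-yl)methyl group, the same new group gives a 1.1-fold higher number from compound 2 to compound 4 (0.02 log units; within the scatter) and again shows no real change. Compound 2, compound 3 and compound 4 therefore stand level, so in these three compounds this place accepts a five-membered ring, a six-membered ring bearing an acetyl group, or a pyrimidine without a shift in the number. On these data alone, whether a carboxylic acid or a long unbranched carbon chain on this nitrogen would also leave the number level stays open. No measurement shown gives a reason why these groups stand level.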